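A few compounds are considered here, and "the series" means these few. Any claim that something is new, unique, unknown or untested is made for them only; others in the source may bear on it.

Compound 1 `CO/C(C)=N\S(=O)(=O)c1ccc(C)cc1` gives 0.135 h in an ADME assay on the whole organism (plasma) for pharmacokinetics, with Homo sapiens as the target, in phosphate buffer, at pH 7.4; on this read-out higher numbers stand for a longer-lived compound and lower numbers for a shorter-lived compound. Compound 2 `CCO/C(C)=N\S(=O)(=O)c1ccc(C)cc1` carries methyl in place of hydrogen on a saturated chain carbon bound to an oxygen on an unsaturated carbon; in this assay compound 2 gives 0.107 h, so that a 1.3-fold lower number from compound 1 to compound 2 (0.10 log units; within the scatter). Compound 3 `CCO/C(=N\S(=O)(=O)c1ccc(C)cc1)c1ccccc1` is built on a different core; in this assay compound 3 gives 0.333 h, a step in which a 3.1-fold higher number from compound 2 to compound 3 (0.49 log units; beyond the scatter). Compound 4 `CCCO/C(=N\S(=O)(=O)c1ccc(C)cc1)c1ccccc1` is not yet measured. Against compound 3 it shows (methyl in place of hydrogen on a saturated chain carbon, two bonds along the chain from an oxygen on an unsaturated carbon). Among the compounds with values here, this is the same kind of change as the one from compound 1 to compound 2, though the place differs: there the carbon was bound to an oxygen on an unsaturated carbon, here it lies two bonds along the chain from an oxygen on an unsaturated carbon. How the core of compound 1 differs from the core of compound 3 is not broken down here. Since a 1.3-fold lower number from compound 1 to compound 2 (0.10 log units; within the scatter) in this assay, the expected step here is similarly small: a 1.1-fold lower number from compound 3 to compound 4 (0.05 log units; within the scatter). Compound 4 is therefore estimated at 0.3 h, between 0.15 h and 0.6 h.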

Compound 4, half-life: 0.333 h
Compound 4: the middle estimate sits 1.1-fold (0.05 log units) below what was measured, and the stated range covers the measured number.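

Going from ethoxy to propoxy gives no change at the digits printed from compound 3 to compound 4 (within the scatter). Adding a methyl to the chain on the two cores gives steps that do not differ beyond the scatter: the same change on two cores in this assay, a 1.3-fold lower number (0.10 log units; within the scatter) from compound 1 to compound 2 and no change at the digits printed (within the scatter) from compound 3 to compound 4, 1.3-fold (0.10 log units) apart, within the scatter of two such steps. Within the data shown here, this suggests that, in these two cases, the small size of the step carries from one core to the other, but it rests on only two steps, the methyl sits at a different place on the chain in each, and neither step is large enough to show that a real effect transfers.

The compounds shown stop at propoxy, so the effect of a longer chain, or of an amine in its place, stays open. Going by these compounds, whether the step holds on any further core also stays open.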